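Indolylsulfanyl pyrimidinyl ureas: swapping the anilino substituent

The compounds below may be only part of what the source reports. "The series", "measured", "known", "first", "only" and "open" are said of these compounds alone.

All numbers come from a functional assay on HepG2 cells (Homo sapiens) for inhibition, with a stated time of 72 h; a higher number here means a weaker inhibitor, a lower number a stronger inhibitor.

Compound 1 `O=C(Nc1ccccc1)Nc1nc(Sc2c[nH]c3ccccc23)cc(N2CCN(Cc3ccccc3)CC2)n1`: 8160 nM
Compound 2 `O=C(Nc1ccccc1)Nc1nc(Nc2ccccc2)cc(Sc2c[nH]c3ccccc23)n1`: 14400 nM
Compound 3 `O=C(Nc1ccccc1)Nc1nc(Nc2ccc(Cl)cc2)cc(Sc2c[nH]c3ccccc23)n1`: 12600 nM

Compound 3 stands second highest of the three numbers; its nearest neighbour is compound 2 and its furthest is compound 1, and both gaps lie within the scatter. For the measured compounds named here, the one counted step among the measured compounds, a 1.1-fold lower number from compound 2 to compound 3 (0.06 log units; within the scatter), is within the scatter and does not touch the part of the structure altered next.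

Compound 4 `O=C(Nc1ccccc1)Nc1nc(Sc2c[nH]c3ccccc23)cc(N2CCN(c3ccccn3)CC2)n1` is the next member. The change from compound 3 is 4-(pyridin-2-yl)piperazin-1-yl in place of (4-chlorophenyl)amino on an aromatic carbon. Going by the values given here, no measured step covers this exchange. Compound 1 gives 8160 nM and compound 3 gives 12600 nM, numbers within the scatter of each other, and all three measured values sit close together. The step of a 1.4-fold lower number from compound 3 to compound 4 (0.15 log units; within the scatter) is therefore expected to be small, with no direction beyond the scatter. Compound 4 is estimated at 9000 nM, within 3500 nM to 25000 nM.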

Compound 4, half-maximal inhibitory concentration: 8930 nM
For compound 4 the middle estimate is 1.0-fold (0.00 log units) above the measured one, within the range that was stated.
By their numbers in this assay, from the lowest: compounds 1, 4, 3 and 2 (each within the scatter of the next).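

In this assay the exchange of (4-chlorophenyl)amino for 4-(pyridin-2-yl)piperazin-1-yl on the shared core gives a 1.4-fold lower number from compound 3 to compound 4 (0.15 log units; within the scatter) and the exchange of anilino for the same group gives a 1.6-fold lower number from compound 2 to compound 4 (0.21 log units; within the scatter) as its counterpart. At the amine nitrogen in the ring, pyridin-2-yl in place of benzyl gives a 1.1-fold higher number from compound 1 to compound 4 (0.04 log units; within the scatter) as the first step read at that far end of the substituent. At this position, then, 1 hydrogen-bond donor in the leaving groups and 0 hydrogen-bond donors in the entering group stand with no step beyond the scatter.

Still open, from the compounds shown here alone, is whether a smaller group here, such as morpholin-4-yl or dimethylamino, gives a step beyond the scatter. Also open, going by these compounds, is whether a carboxylic acid on the far ring does so. No supporting data explain why these numbers stay together.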